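The source may hold more compounds than are shown below. What is called first, only, known or untested is meant among the compounds shown, and "the series" means these compounds.

Measured compounds:

Compound 1, `Cc1ccc2nc(Nc3nc(Nc4ccc(S(N)(=O)=O)cc4)ncc3F)sc2c1`, gives 1890 nM in a functional assay on HeLa cells (Homo sapiens) for antiproliferative activity, read by MTT assay, with a stated time of 48 h; a lower number here means a stronger inhibitor, a higher number a weaker inhibitor.
Compound 2, `NS(=O)(=O)c1ccc(Nc2ncc(F)c(Nc3nc4ccccc4s3)n2)cc1`, gives 4520 nM in this assay.
Compound 3, `CS(=O)(=O)c1ccc(Nc2nccc(Nc3nc4ccc(F)cc4s3)n2)cc1`, gives 560 nM in this assay.

Compound 3 stands lowest of the three in this assay, its steps to compound 1 and to compound 2 both lying beyond the scatter. Compound 1 and compound 2 share one core, and the change from compound 2 to compound 1 is methyl in place of hydrogen on an aromatic carbon. That change gives a 2.4-fold lower number from compound 2 to compound 1 (0.38 log units; beyond the scatter). The core of compound 3 differs from the core of compound 2 in more than one place, and the difference between the two cores is not broken down here.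

Compound 4, `Cc1cnc(Nc2ccc(S(C)(=O)=O)cc2)nc1Nc1nc2ccc(F)cc2s1`, has not yet been measured. It differs from compound 3 by methyl in place of hydrogen on an aromatic carbon. For the measured compounds named here, this is the same kind of change as the one from compound 2 to compound 1, but not the same change: there the methyl entered on a six-membered aromatic ring of carbon only, part of a fused or bridged system of two rings, meta to a fused ring and para to a fused ring; here it enters on a six-membered aromatic ring with 2 nitrogen, ortho to a large group, two atoms from the ring nitrogen, and para to a large group. Going by the values given here, the only guide is the step from compound 2 to compound 1, which is modest and beyond the scatter. The place of the methyl differs from that earlier one, and the expected step is kept smaller: a 1.3-fold lower number from compound 3 to compound 4 (0.12 log units; within the scatter). Compound 4 is therefore expected to give 420 nM in this assay, with a likely range from 150 nM to 1200 nM.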

Compound 4, half-maximal inhibitory concentration: > 50000 nM
Compound 4: no number, only a limit (the forecaster's own chance of this, stated with the estimate: 3%); middle value at least 110-fold (2.07 log units) away from the limit.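

Compound 4 gives > 50000 nM in this assay, and this is a limit of the assay, not a number: the limit of > 50000 nM in this assay, at which 1 of the 4 values shown sits.

Methyl in place of hydrogen on an aromatic carbon gives an at least 89-fold higher number from compound 3 to compound 4 (1.95 log units; beyond the scatter), whereas the same kind of change on the other core gave a 2.4-fold lower number from compound 2 to compound 1 (0.38 log units; beyond the scatter), so in this series the effect of the change does not carry from one core to another: the same change on two cores in this assay, a 2.4-fold lower number (0.38 log units; beyond the scatter) from compound 2 to compound 1 and an at least 89-fold higher number (1.95 log units; beyond the scatter) from compound 3 to compound 4, at least 210-fold (2.32 log units) apart, beyond the scatter of two such steps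

What this does not show is which difference between the two pairs matters, since the methyl sits on a six-membered aromatic ring of carbon only in compound 1 and on a six-membered aromatic ring with 2 nitrogen in compound 4, and the two cores also differ in more than one other place. With one pair on each core, the ring that carries the methyl cannot be separated from the rest of the core.

The compounds shown leave open whether the large step is specific to methyl, as nothing here shows what an ethyl, a methoxy or an amine would do in the same place on the core of compound 3. They also leave open whether a methyl on other ring carbons of that core would give a step closer to the modest one seen on the other core.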